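Methoxycarbonyl in place of bromo: a second instance

The compounds below may be only part of what the source reports. "The series", "measured", "known", "first", "only" and "open" are said of these compounds alone.

Measured in an assay on HEK293 cells for displacement of a labelled ligand from prostaglandin D2 receptor 2 (Homo sapiens); on this read-out higher numbers stand for weaker inhibition and lower numbers for stronger inhibition:
compound 1 `O=C(O)Cn1c(SCc2ccc(Br)cc2)nc2ccccc21`: 220 nM
compound 2 `O=C(O)Cn1c(SCc2cccc(Br)c2)nc2ccccc21`: 370 nM
compound 3 `COC(=O)c1ccc(CSc2nc3ccccc3n2CC(=O)O)cc1`: 10600 nM

Compound 2 differs from compound 1 by 3-bromophenyl in place of 4-bromophenyl on a saturated chain carbon bound to a sulfur; the step of a 1.7-fold higher number from compound 1 to compound 2 (0.23 log units; within the scatter) lies within the scatter. Compound 3 differs from compound 1 by methoxycarbonyl in place of bromo on an aromatic carbon, giving a 48-fold higher number from compound 1 to compound 3 (1.68 log units; beyond the scatter). Compound 4 `COC(=O)c1cccc(CSc2nc3ccccc3n2CC(=O)O)c1` differs from compound 2 by methoxycarbonyl in place of bromo on an aromatic carbon. This is the same kind of change as that from compound 1 to compound 3, not the same: there the group sits para to a large group, here meta to a large group. The change occurs twice among these compounds and only the first instance is measured. Within the data shown here, for compound 4 the expected step in this assay is a 41-fold higher number from compound 2 to compound 4 (1.61 log units; beyond the scatter), resting on the single measured example a 48-fold higher number from compound 1 to compound 3 (1.68 log units; beyond the scatter). The estimate for compound 4 is 15000 nM, with a range from 5000 nM to 50000 nM.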

Compound 4, half-maximal inhibitory concentration: 450 nM
Beside the measured number, compound 4's estimate is 33-fold (1.52 log units) above it; measured number below the stated range.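

In this assay, methoxycarbonyl in place of bromo does not carry over from one core to the other as a fixed step: the same change on two cores in this assay, a 48-fold higher number (1.68 log units; beyond the scatter) from compound 1 to compound 3 and a 1.2-fold higher number (0.09 log units; within the scatter) from compound 2 to compound 4, 40-fold (1.60 log units) apart, beyond the scatter of two such steps

The step here is a 1.2-fold higher number from compound 2 to compound 4 (0.09 log units; within the scatter), with the group meta to a large group, so the large step seen from compound 1 to compound 3 cannot be assumed for this change across the series. Among these compounds, with only one pair on each core, the data do not show whether the position of the group alone separates the two steps, and they give no cause for the gap.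

On these data alone, whether a carboxylic acid or a nitrile in place of bromo would give the same contrast between the two cores remains open. Also open, as far as these compounds go, is whether the gap holds for other groups in place of bromo, such as an amide.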